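The compounds below may be only part of what the source reports. "The series", "measured", "known", "first", "only" and "open" are said of these compounds alone.

In a functional assay on Bel-7402 cells (Homo sapiens) for cytotoxicity, read by MTT assay (on this read-out lower numbers stand for stronger inhibition and higher numbers for weaker inhibition), compound 2 `Cc1cccc(Nc2nc(C)c(C(=O)/C=C/c3ccccc3Cl)s2)c1` gives > 25000 nM, which is a limit of the assay rather than a number. Compound 1 `Cc1nc(Nc2cccc(Cl)c2)sc1C(=O)/C=C/c1ccccc1` likewise gives > 25000 nM, again a limit. Compound 3 `Cc1nc(Nc2ccccc2)sc1C(=O)/C=C/c1ccc(Cl)cc1` gives > 25000 nM, also a limit. Compound 2 therefore stands level with the other two, all three resting at the limit of > 25000 nM in this assay, at which 3 of the 3 values shown sit, with no order among them. Compound 4 `Cc1cccc(Nc2nc(C)c(C(=O)/C=C/c3ccccc3)s2)c1` has not been measured in this assay; it differs from compound 2 by hydrogen in place of chloro on an aromatic carbon. Going by the values given here, with every measured value a limit, no measured step offers a size to expect, and the step that the limit leaves unreadable from compound 2 to compound 4 is expected to be none beyond the scatter. Compound 4 is accordingly estimated at 35000 nM, within 8000 nM to 150000 nM, most likely reported again only as a limit.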

Compound 4, half-maximal inhibitory concentration: > 25000 nM
Compound 4: no number, only a limit (the forecaster's own chance of this, stated with the estimate: 85%); the middle value lies beyond the limit too.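

The steps from compound 2 and from compound 1 to compound 4 cannot be read, since all the values in this assay are limits: the limit of > 25000 nM in this assay, at which 4 of the 4 values shown sit.

The compounds shown leave open what size, if any, the change from 2-chlorophenyl to phenyl has.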